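Amino acid side-arm variation on a combretastatin-type stilbene scaffold

A few compounds are considered here, and "the series" means these few. Any claim that something is new, unique, unknown or untested is made for them only; others in the source may bear on it.

Measured compounds in a functional assay on MC-38 cells (Mus musculus) for antiproliferative activity, read by CCK-8 assay, with a stated time of 48 h; on this read-out higher numbers stand for weaker inhibition and lower numbers for stronger inhibition:
- Compound 1, `COc1ccc(/C=C\c2cc(OC)c(OC)c(OC)c2)cc1OCc1ccc(CN[C@H](C(=O)O)[C@H](C)O)cc1`: compound 1 reports only the assay limit, > 10000 nM.
- Compound 2, `COc1ccc(/C=C\c2cc(OC)c(OC)c(OC)c2)cc1OCc1ccc(CN2CC[C@H](O)C2)cc1`: compound 2 gives 7200 nM.
- Compound 3, `COc1ccc(/C=C\c2cc(OC)c(OC)c(OC)c2)cc1OCc1ccc(CO)cc1`: compound 3 gives 5700 nM.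

Compound 1 stands at the weak end of the set: its value is a limit, not a number, as noted in the limit of > 10000 nM in this assay, at which 1 of the 3 values shown sits. The two steps that leave compound 1 are an at least 1.3-fold lower number from compound 1 to compound 2 (0.14 log units; that floor lies within the scatter) and an at least 1.7-fold lower number from compound 1 to compound 3 (0.24 log units; that floor lies within the scatter); both run toward lower numbers, but both are floors and neither clears the scatter. The step between the two numbered compounds, a 1.3-fold lower number from compound 2 to compound 3 (0.10 log units; within the scatter), also lies within the scatter, so the three measured values cannot be ordered with confidence.

Compound 4, `COc1ccc(/C=C\c2cc(OC)c(OC)c(OC)c2)cc1OCc1ccc(CNC(C)(C)C(=O)O)cc1`, is the untested analogue. It differs from compound 1 by 1-carboxy-1-methylethyl in place of 1-carboxy-2-hydroxypropyl on an amine nitrogen. Going by the values given here, the carboxy group on the amine side-arm is kept, so compound 4 stays closest to compound 1 among the three measured compounds, and no measured step supports a shift beyond the scatter. Accordingly the step is expected to be about a step that the limit leaves unreadable from compound 1 to compound 4, with a real chance that only a limit is reported again. Compound 4 is therefore estimated at 12000 nM, within 5000 nM to 30000 nM.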

Compound 4, half-maximal inhibitory concentration: > 10000 nM
Compound 4 was reported as a limit; the forecaster's own chance of this, stated with the estimate: 55%; the middle value is on the limit's open side.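

In this assay compound 4 gives > 10000 nM, which is a limit of the assay and not a number. The step involving compound 1 and compound 4 cannot be read, and a side-arm with a carboxy group but without the hydroxy group and the defined stereocentres of 1-carboxy-2-hydroxypropyl also sits at the limit: the limit of > 10000 nM in this assay, at which 2 of the 4 values shown sit.

Against the two compounds without a carboxy group, the readings are an at least 1.7-fold higher number from compound 3 to compound 4 (0.24 log units; that floor lies within the scatter) and an at least 1.3-fold higher number from compound 2 to compound 4 (0.14 log units; that floor lies within the scatter); both are floors, so no real separation of the (1-carboxy-1-methylethyl)amino side-arm from hydroxy or 3-hydroxypyrrolidin-1-yl is established.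

Still open, on these data alone, is whether the carboxylic acid itself ties these side-arms to the limit, a question that a methyl ester or a primary amide in its place on the same side-arm would address. Also open, as far as these compounds go, is whether a longer chain between the amine nitrogen and the carboxylic acid would bring a readable value in this assay.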